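Replacing methylsulfanyl with hydroxy in compound 2

This account rests on a few compounds, and the source may have more. Where it says the series, first, only, none or still open, it means among the compounds named here.

compound 1 `COc1cccc([C@@H]2[C@H](Oc3ccccc3)C(=O)N2c2cc(OC)c(OC)c(OC)c2)c1` gives 171000 nM
compound 2 `COc1cc(N2C(=O)[C@@H](Oc3ccccc3)[C@H]2c2ccc(SC)cc2)cc(OC)c1OC` gives 7700 nM

In a functional assay on MCF7 cells (Homo sapiens) for antiproliferative activity, read by MTT assay, with stated times of 24 h and 72 h (on this read-out lower numbers stand for stronger inhibition and higher numbers for weaker inhibition), compound 2 has the lower of the two numbers at 7700 nM and compound 1 has the higher one. Compound 3 `COc1cc(N2C(=O)[C@@H](Oc3ccccc3)[C@H]2c2ccc(O)cc2)cc(OC)c1OC` carries hydroxy in place of methylsulfanyl on an aromatic carbon and has not yet been measured. Among the compounds with values here, one measured step bears on this, the swap to 4-(methylsulfanyl)phenyl in place of 3-methoxyphenyl, which gave a 22-fold lower number from compound 1 to compound 2 (1.35 log units; beyond the scatter) and was large. Removing methylsulfanyl may undo part of that drop, so a moderate rise, smaller than that step, is expected. In this assay the expected step is a 2.6-fold higher number from compound 2 to compound 3 (0.41 log units; beyond the scatter) by this estimate. Compound 3 is expected at about 20000 nM with 5000 nM to 80000 nM as its range.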

Compound 3, half-maximal inhibitory concentration: 48000 nM
Compound 3: middle estimate off by 2.4-fold (0.38 log units), on the low side; measured number inside the range.
By their numbers in this assay, from the lowest: compound 2; then compound 3; then compound 1.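

In this assay, the group on this aromatic carbon matters: hydroxy in place of methylsulfanyl gives a 6.2-fold higher number from compound 2 to compound 3 (0.79 log units; beyond the scatter), so inhibition weakens. Even so, 4-hydroxyphenyl in place of 3-methoxyphenyl gives a 3.6-fold lower number from compound 1 to compound 3 (0.55 log units; beyond the scatter), so part of the earlier gain survives without methylsulfanyl. No measurement here explains the difference between these groups. On these data alone, it remains open whether an amine or a chlorine atom on this carbon would give a number nearer that of methylsulfanyl or that of hydroxy. As far as these compounds go, a longer chain on the sulfur is equally open.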